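The compounds below may be only part of what the source reports. "The series", "measured", "known", "first", "only" and "open" are said of these compounds alone.

Working notes on the series. In an ADME assay on microsomes from liver (Rattus norvegicus) for metabolic stability, read by HPLC, using NADPH, with stated times of 5 min and 60 min, tested at 10 uM (a higher number here means faster removal of the compound, a lower number slower removal), compound 1 (`Cn1cc(-c2cc(C(N)=O)ccc2Oc2ccccc2)c2cc[nH]c2c1=O`) gives 550 mL/min/kg while compound 2 (`CCS(=O)(=O)Nc1ccc(Oc2ccc(C(F)(F)F)cc2)c(-c2cn(C)c(=O)c3[nH]ccc23)c1`) gives 583 mL/min/kg and compound 3 (`Cn1cc(-c2cc(NS(C)(=O)=O)ccc2Oc2ccc(F)cc2Cl)c2cc[nH]c2c1=O`) gives 317 mL/min/kg on the same read-out. Compound 3 lies within the scatter of both other compounds, so these three numbers set no order among them.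

Compound 4 (`Cn1cc(-c2cc(NS(C)(=O)=O)ccc2OC2CCC(F)(F)CC2)c2cc[nH]c2c1=O`) is the next to be read. It carries 4,4-difluorocyclohexyl in place of 2-chloro-4-fluorophenyl on an oxygen on an aromatic ring, with the rest of compound 3 unchanged.

Within the data shown here, no pair of measured compounds differs in one place only, so the series offers no direct measure of this change. The three measured compounds differ from one another in more than one place, yet all of them lie within the scatter of each other. On that limited basis, no step beyond the scatter is expected in this assay, and neither direction is favoured. Among the measured compounds shown here, the expected change is small: a 1.1-fold lower number from compound 3 to compound 4 (0.02 log units; within the scatter) as estimated here, and the uncertainty remains wide because the new ring type has no measured counterpart. For compound 4 the estimated clearance is 300 mL/min/kg with an expected range from 150 mL/min/kg to 600 mL/min/kg in this assay when it is measured.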

Compound 4, clearance: 200 mL/min/kg
Compound 4: the middle estimate sits 1.5-fold (0.18 log units) above what was measured, and the stated range covers the measured number.
By their numbers in this assay, from the lowest: compounds 4, 3, 1 and 2 (each within the scatter of the next, the first and the last beyond it).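

The step on an oxygen on an aromatic ring gives the series its first direct reading of a change in one place in this assay, namely a 1.6-fold lower number from compound 3 to compound 4 (0.20 log units; within the scatter), with 4,4-difluorocyclohexyl in place of 2-chloro-4-fluorophenyl. A six-membered non-aromatic ring of carbon only can therefore stand at this oxygen with the read-out staying within the scatter of the compound with the aromatic ring, so this exchange of rings, with chlorine leaving and a second fluorine entering, does not separate the two compounds. Nothing at hand bears on the reason for this result.

The compounds shown leave open how a cyclohexyl without fluorine, a piperidinyl ring carrying a basic amine, or a cyclohexyl bearing a carboxylic acid would read at this oxygen, and so whether any group here can move the number beyond the scatter. They also leave open whether the same exchange of rings would read alike on the carboxamide of compound 1 or the ethylsulfonyl amide of compound 2.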